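The compounds below may be only part of what the source reports. "The series", "measured", "known", "first", "only" and "open" are said of these compounds alone.

Two compounds of the series have so far been run in an ADME assay on J774 cells (Mus musculus, strain BALB/c) for cytotoxicity, read by resazurin assay, with a stated time of 72 h; on this read-out lower numbers stand for higher toxicity in this test and higher numbers for lower toxicity in this test. Compound 1 `CC(/C=N/Nc1ccc([N+](=O)[O-])cc1)=N\NC(=O)c1ccccc1Nc1ccccc1` gives only a limit there, > 100000 nM. This is the limit described as the limit of > 100000 nM in this assay, at which 1 of the 2 values shown sits. Among the measured compounds shown here, compound 2 `CC(/C=N/Nc1ccc([N+](=O)[O-])cc1)=N\NC(=O)c1ccc(O)cc1` gives 51000 nM, the one actual number among the results in this assay. Compound 3 `CC(/C=N/Nc1ccc([N+](=O)[O-])cc1)=N\NC(=O)c1ccccc1F` differs from compound 2 in a single place: 2-fluorophenyl in place of 4-hydroxyphenyl on a carbonyl carbon. For the measured compounds named here, no measured step between two compounds is available for comparison, so the expected step in this assay is small, within the scatter, a 1.2-fold higher number from compound 2 to compound 3 (0.07 log units; within the scatter). Compound 3 is therefore estimated at 60000 nM, between 20000 nM and 150000 nM in this assay.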

Compound 3, half-maximal cytotoxic concentration: > 100000 nM
Compound 3: only a limit was reported; the forecaster's own chance of this, stated with the estimate: 40%; middle value at least 1.6-fold (0.22 log units) away from the limit.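

On a carbonyl carbon whose other neighbours are an amide-type nitrogen, 2-fluorophenyl in place of 4-hydroxyphenyl gives, in this assay, an at least 1.9-fold higher number from compound 2 to compound 3 (0.29 log units; that floor lies within the scatter). That step is only a floor, as compound 3 gives a limit rather than a number, so a ring without the hydroxy group brings no lower number here. The steps involving compound 1 cannot be read, and compound 2 keeps the only actual number, as the other two compounds sit at a limit: the limit of > 100000 nM in this assay, at which 2 of the 3 values shown sit.

Still open, from the compounds shown here alone, is how far compound 3 lies past its limit. Also open, going by these compounds, is whether an aminophenyl or carboxyphenyl group at this place, or a longer chain, would give a readable number.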